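The source may hold more compounds than are shown below. What is called first, only, known or untested is meant among the compounds shown, and "the series" means these compounds.

The measured compounds:

compound 1 `CCCCC(CC)C(=O)Nc1ccc2ccn(Cc3ccc(C(=O)NS(=O)(=O)c4ccc(Cl)cc4)cc3OC)c2c1` with 7.8
compound 2 `COc1cc(C(=O)NS(=O)(=O)c2cc(C)ccc2C)ccc1Cn1ccc2ccc(NC(=O)CC3CCCC3)cc21` with 8.4
compound 3 `COC(=O)C(C(=O)c1ccc(Cn2ncc3ccc(NC(=O)OC4CCCC4)cc32)c(OC)c1)S(=O)(=O)c1ccccc1` with 9.9

In a functional assay (trachea) for antagonist activity, with Cavia porcellus as the target (a higher number here means a more potent compound, by a factor of ten per unit of this negative logarithm, a lower number a less potent compound), compound 2 gives 8.4. Among the three numbers this places compound 2 second highest: compound 1 lies lower, with its value of 7.8 sitting beyond the usual scatter below compound 2, and compound 3 lies higher, with its value of 9.9 standing well beyond the scatter above compound 2. No two of these compounds differ in a single place, so none of these gaps can be tied to one structural change.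

Compound 4 `COc1cc(C(=O)NS(=O)(=O)c2c(C)cccc2Cl)ccc1Cn1ccc2ccc(NC(=O)CC3CCCC3)cc21` has not been measured in this assay. It differs from compound 2 in one place: 2-chloro-6-methylphenyl in place of 2,5-dimethylphenyl on a sulfonyl sulfur. Among the measured compounds shown here, no measured pair shows this kind of change, so its effect in this assay is not known from the data. Given that compound 2 gives 8.4, compound 4 is expected to stay close to it, with a step of a number 0.10 log units lower from compound 2 to compound 4 (within the scatter) that would fall within the scatter. The estimate for compound 4 is 8.3, within a range from 7.7 to 8.9.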

Compound 4, negative logarithm of the antagonist equilibrium constant: 8.8
Compound 4: middle estimate off by 0.50 log units, on the low side; the measured number falls inside the stated range.
By their numbers in this assay, from the lowest: compound 1; then compound 2; then compound 4; then compound 3.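

Among the compounds shown here, this is the first single-place comparison in the set, and it shows that the aryl group on a sulfonyl sulfur can move the number in this assay: replacing 2,5-dimethylphenyl with 2-chloro-6-methylphenyl gives a number 0.40 log units higher from compound 2 to compound 4 (beyond the scatter). The step is modest, yet it comes from an exchange in which the heavy-atom count stays the same and neither group carries hydrogen-bond donors, hydrogen-bond acceptors or a net charge. No available evidence bears on the reason for this step.

The compounds shown cannot separate the entry of the chlorine from the different placement of the groups on the ring. They also leave open how a thiophene ring or a plain methyl group would fare on the sulfonyl sulfur.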